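Swapping One Side Group on Compound 3

A few compounds are considered here, and "the series" means these few. Any claim that something is new, unique, unknown or untested is made for them only; others in the source may bear on it.

Compound 1 `Cc1cc(C)c(CN2CCc3c(Cl)cc(C(CO)c4ccon4)c(Cl)c3C2=O)c(=O)[nH]1`: 5.8 10^-6 cm/s; 8.6 10^-6 cm/s (2 entries)
Compound 2 `CCOC(c1cc(Cl)c2c(c1Cl)C(=O)N(Cc1c(C)cc(C)[nH]c1=O)CC2)C1CS(=O)(=O)C1`: 12 10^-6 cm/s; 7.7 10^-6 cm/s (2 entries)
Compound 3 `Cc1cc(C)c(CN2CCc3c(Cl)cc([C@@H](C)CO)c(Cl)c3C2=O)c(=O)[nH]1`: 15 10^-6 cm/s

In an ADME assay on MDCK cells (Canis lupus familiaris) for permeability, read by LC-MS, with a stated time of 90 min, tested at 2 uM (a lower number here means that the compound crosses the layer more slowly, a higher number that the compound crosses the layer faster), compound 3 has just one entry, 15 10^-6 cm/s, while the other two compounds each have a pair of entries: the several entries of compound 1 in this assay, 5.8 10^-6 cm/s; 8.6 10^-6 cm/s (2 entries) and (the several entries of compound 2 in this assay, 12 10^-6 cm/s; 7.7 10^-6 cm/s (2 entries)).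

The next compound to be tested is compound 4 `Cc1cc(C)c(CN2CCc3c(Cl)cc(-c4c(C)noc4C)c(Cl)c3C2=O)c(=O)[nH]1`, which keeps the shared core and changes one group: 3,5-dimethyl-1,2-oxazol-4-yl in place of 1-(hydroxymethyl)ethyl on an aromatic carbon. In words, 3,5-dimethyl-1,2-oxazol-4-yl stands in place of 1-(hydroxymethyl)ethyl on an aromatic carbon.

Among the measured compounds shown here, no two measured compounds differ in one place only, so the data give no direct guide to this swap. The expectation therefore starts from compound 3 at 15 10^-6 cm/s and assumes no change beyond the scatter in this assay in either direction. The expected result is a 1.1-fold lower number from compound 3 to compound 4 (0.03 log units; within the scatter) and this remains only an estimate. For compound 4 the estimated value is 14 10^-6 cm/s with an expected range from 6 10^-6 cm/s to 30 10^-6 cm/s.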

Compound 4, apparent permeability in the MDCK assay: 15.7 10^-6 cm/s
Compound 4: middle estimate off by 1.1-fold (0.05 log units), on the low side; measured number inside the range.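

In the MDCK assay compound 3 gives 15 10^-6 cm/s and compound 4 gives 15.7 10^-6 cm/s. In the MDCK assay the swap gives a 1.0-fold higher number from compound 3 to compound 4 (0.02 log units; within the scatter), on an aromatic carbon ortho to a chloro group. In a physicochemical assay for solubility, measured as kinetic solubility (on this read-out lower numbers stand for lower solubility and higher numbers for higher solubility), compound 3 gives 143000 nM and compound 4 gives 93000 nM. In the physicochemical assay the swap gives a 1.5-fold lower number from compound 3 to compound 4 (0.19 log units; within the scatter), so neither read-out separates the open chain 1-(hydroxymethyl)ethyl, with its hydrogen-bond donor and defined stereocentre, from the larger aromatic ring 3,5-dimethyl-1,2-oxazol-4-yl, which has no donor. The data shown offer no explanation for this lack of change.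

The swap alters size, ring, donor count and stereocentre all at once, so the compounds shown cannot tell these features apart. From the compounds shown here alone, whether a very different group at this place, such as an amine or a carboxylic acid, would also leave both read-outs unchanged remains open.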